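Swapping the aryl group on the shared core of compound 1

The source may report more compounds than this note shows. Statements on the series, on what has been measured and on what is new or still open speak of the compounds shown alone.

This account follows three compounds built on one shared core, which differ only in the aryl group attached to it. Compound 1 `C=CS(=O)(=O)N1CCN(c2ncnc3sc(-c4ccc(C#N)cc4)cc23)CC1` carries 4-cyanophenyl and gives 9170 nM in a functional assay on MDA-MB-436 cells (Homo sapiens) for antiproliferative activity, read by MTT assay, with a stated time of 48 h; a lower number here means a stronger inhibitor, a higher number a weaker inhibitor. Compound 2 `C=CS(=O)(=O)N1CCN(c2ncnc3sc(-c4cccc5ncccc45)cc23)CC1` gives 25900 nM, and compound 3 `C=CS(=O)(=O)N1CCN(c2ncnc3sc(-c4ccc(OC)nc4)cc23)CC1` gives 11900 nM. Compound 1 has the lowest of these three numbers; compound 3 sits nearest to it and compound 2 furthest, as the steps of a 1.3-fold higher number from compound 1 to compound 3 (0.11 log units; within the scatter) and a 2.8-fold higher number from compound 1 to compound 2 (0.45 log units; beyond the scatter) show.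

Compound 4 `C=CS(=O)(=O)N1CCN(c2ncnc3sc(-c4cccs4)cc23)CC1` has not yet been measured in this assay. It differs from compound 1 by thiophen-2-yl in place of 4-cyanophenyl on an aromatic carbon. Of the measured steps, the step of a 1.3-fold higher number from compound 1 to compound 3 (0.11 log units; within the scatter) to another aryl group left the number essentially unchanged, whereas the step of a 2.8-fold higher number from compound 1 to compound 2 (0.45 log units; beyond the scatter) to a larger two-ring group raised it modestly. Among the measured compounds shown here, a small five-membered ring has no direct precedent here, so a step of uncertain direction, likely no larger than that to compound 2, is expected: a 1.3-fold higher number from compound 1 to compound 4 (0.12 log units; within the scatter). Compound 4 is therefore estimated to give about 12000 nM, within 5000 nM to 35000 nM.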

Compound 4, half-maximal inhibitory concentration: 39000 nM
Compound 4: the middle estimate sits 3.3-fold (0.51 log units) below what was measured; the whole stated range lies below it.
By their numbers in this assay, from the lowest: compounds 1 and 3 (each within the scatter of the next); then compounds 2 and 4 (each within the scatter of the next).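

In this assay, thiophen-2-yl on this aromatic carbon next to the ring sulfur brings in a five-membered ring, and the change gives a 4.3-fold higher number from compound 1 to compound 4 (0.63 log units; beyond the scatter) and also a 3.3-fold higher number from compound 3 to compound 4 (0.52 log units; beyond the scatter) as its step from 6-methoxypyridin-3-yl. A group with fewer heavy atoms than 4-cyanophenyl therefore does not hold the number, and the step of a 1.5-fold higher number from compound 2 to compound 4 (0.18 log units; within the scatter) leaves it within the scatter of the two-ring quinolin-5-yl group, so across these four compounds the number does not follow group size in one direction. Only compounds 1 and 3, each with a single six-membered ring here, stay together at the low end.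

From the compounds shown here alone, whether a plain phenyl or a phenyl carrying an amine or a carboxylic acid in place of the nitrile would keep that low end remains open, as does whether a furan would behave like thiophen-2-yl. The data shown offer no measured explanation for these differences.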